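The source may report more compounds than this note shows. Statements on the series, on what has been measured and on what is new or still open speak of the compounds shown alone.

Measured so far:
Compound 1 `C/C(=C\CC/C(C)=C/CC[C@@H]1[C@@]2(C)CCC(=O)C(C)(C)[C@H]2CC[C@@]1(C)O)CC/C=C(\C)C(=O)OCc1cn(-c2cccc(O)c2)nn1`: 146000 nM
Compound 2 `C/C(=C\CC/C(C)=C/CC[C@@H]1[C@@]2(C)CCC(=O)C(C)(C)[C@H]2CC[C@@]1(C)O)CC/C=C(\C)C(=O)OCc1cn(-c2ccccc2C(F)(F)F)nn1`: > 150000 nM
Compound 3 `C/C(=C\CC/C(C)=C/CC[C@@H]1[C@@]2(C)CCC(=O)C(C)(C)[C@H]2CC[C@@]1(C)O)CC/C=C(\C)C(=O)OCc1cn(-c2ccccc2)nn1`: > 150000 nM

In an ADME assay on L132 cells (Homo sapiens) for cytotoxicity, read by MTT assay, with a stated time of 48 h (on this read-out higher numbers stand for weaker inhibition and lower numbers for stronger inhibition), compound 1 gives 146000 nM. For compound 2 the read-out is a limit of the assay, > 150000 nM. Compound 3 likewise returns only a limit, > 150000 nM. Compound 3 therefore stands at the limit of > 150000 nM in this assay, at which 2 of the 3 values shown sit, and no number for it is known.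

The two steps that reach compound 3 say little. The step of an at least 1.0-fold higher number from compound 1 to compound 3 (0.01 log units; that floor lies within the scatter) is only a floor, and that floor lies within the scatter. The step that the two limits leave unreadable from compound 2 to compound 3 cannot be read at all, since both ends are limits.

Compound 4 `C/C(=C\CC/C(C)=C/CC[C@@H]1[C@@]2(C)CCC(=O)C(C)(C)[C@H]2CC[C@@]1(C)O)CC/C=C(\C)C(=O)OCc1cn(-c2ccc([N+](=O)[O-])cc2)nn1` differs from compound 3 by nitro in place of hydrogen on an aromatic carbon. Going by the values given here, no measured step introduces a nitro group, so the only bearing comes from the two changes on the same phenyl already seen, both of which left the read-out at or near the limit. The expected step is a number no higher from compound 3 to compound 4 (the limit leaves the size open), that is, none beyond the scatter, with a good chance that compound 4 again returns only a limit.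

Compound 4 is therefore expected near 150000 nM in this assay, with a range from 60000 nM to 350000 nM.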

Compound 4, half-maximal inhibitory concentration: > 150000 nM
Compound 4 gave a limit, no number; the forecaster's own chance of this, stated with the estimate: 65%; the middle value sits exactly at the limit.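

In this assay compound 4 returns only a limit, so nitro on the phenyl, para to a large group, yields no readable number, and the series gathers further at one end of the scale: the limit of > 150000 nM in this assay, at which 3 of the 4 values shown sit. Setting 4-nitrophenyl in place of 3-hydroxyphenyl gives an at least 1.0-fold higher number from compound 1 to compound 4 (0.01 log units; that floor lies within the scatter), so no real separation from the one compound with a number is shown. The steps to compound 4 from compound 2 and from compound 3 cannot be read, as both ends of each are limits.

On these data alone, how far compound 2, compound 3 and compound 4 lie past the limit remains open, and so does any ranking among them. As far as these compounds go, whether this position can bring the read-out clearly below the limit at all also stays open, and an amine or a carboxylic acid on the same phenyl would bear on that question.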